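The source may report more compounds than this note shows. Statements on the series, on what has been measured and on what is new or still open speak of the compounds shown alone.

Measured compounds:
compound 1 `C=C1[C@H](C)CCC[C@]1(C)CC/C(C)=C/CC1=C(O)C(=O)C=C(N[C@@H](C(=O)O)[C@H](C)O)C1=O`: > 10 ug/mL
compound 2 `C=C1[C@H](C)CCC[C@]1(C)CC/C(C)=C/CC1=C(O)C(=O)C=C(N[C@@H](C(=O)O)C(C)C)C1=O`: 6.2 ug/mL
compound 3 `C=C1[C@H](C)CCC[C@]1(C)CC/C(C)=C/CC1=C(O)C(=O)C=C(N[C@H](C(=O)O)[C@H](C)O)C1=O`: > 10 ug/mL

In an ADME assay on KB cells (Homo sapiens) for cytotoxicity, with a stated time of 48 h (on this read-out higher numbers stand for weaker inhibition and lower numbers for stronger inhibition), compound 3 gives > 10 ug/mL, which is a limit of the assay and not a number. Compound 1 likewise gives > 10 ug/mL, also a limit. For the measured compounds named here, compound 2 gives 6.2 ug/mL, the one measured number in the set. Compound 1 and compound 3 differ only in the configuration as drawn, and the step between them is unreadable because of the limit of > 10 ug/mL in this assay, at which 2 of the 3 values shown sit, see a step that the two limits leave unreadable from compound 1 to compound 3.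

Compound 4 `C=C1[C@H](C)CCC[C@]1(C)CC/C(C)=C/CC1=C(O)C(=O)C=C(N[C@H](C(=O)O)C(C)C)C1=O` is the next member. From compound 3 the change is isopropyl in place of 1-hydroxyethyl on a saturated chain carbon bound to an amine nitrogen and a carbonyl carbon.

The same change has been made once already, on the other drawn configuration: an at least 1.6-fold lower number from compound 1 to compound 2 (0.20 log units; that floor lies within the scatter). The reverse reading, an at least 1.6-fold higher number from compound 2 to compound 3 (0.20 log units; that floor lies within the scatter), is the step across both differences. Both only set a floor, yet both point the same way. The expected outcome is therefore a number below the limit, roughly where compound 2 sits: compound 4 is expected to give an at least 1.6-fold lower number from compound 3 to compound 4 (0.22 log units; that floor lies within the scatter), with an estimate of 6 ug/mL and a range of 3 ug/mL to 12 ug/mL.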

Compound 4, half-maximal inhibitory concentration: > 10 ug/mL
Compound 4 gave a limit, no number; the forecaster's own chance of this, stated with the estimate: 35%; middle value at least 1.6-fold (0.22 log units) away from the limit.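

In this assay compound 4 gives > 10 ug/mL, a limit of the assay and not a number. Isopropyl in place of 1-hydroxyethyl on a saturated chain carbon bound to an amine nitrogen and a carbonyl carbon therefore does not give a measured number on this drawn configuration, and the steps with a limit at both ends cannot be read. For the compounds shown here, the only readable new step is an at least 1.6-fold higher number from compound 2 to compound 4 (0.20 log units; that floor lies within the scatter), and this floor alone does not establish a difference beyond the usual scatter for the one change involved: the fact that compounds 2 and 4 differ only in the configuration as drawn.

As far as these compounds go, whether the drawn configuration matters in this isopropyl pair stays open, with most of the series sitting at one limit: the limit of > 10 ug/mL in this assay, at which 3 of the 4 values shown sit. From the compounds shown here alone, how a benzyl group or a longer alkyl chain in place of isopropyl would read also stays open.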